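Ester and carbamate variants of a shared core

The compounds below may be only part of what the source reports. "The series", "measured", "known", "first", "only" and "open" are said of these compounds alone.

Measured so far:
compound 1 `CC1=CC[C@H](C(C)C)c2cc(C)c(OC(=O)c3cccc(C(F)(F)F)c3)cc21` — 86%
compound 2 `CC1=CC[C@H](C(C)C)c2cc(C)c(OC(=O)Nc3ccccc3)cc21` — 75.1%

Both numbers come from a functional assay on MCF7 cells (Homo sapiens) for antiproliferative activity, read by sulforhodamine B assay, with a stated time of 48 h, tested at 50 uM; a lower number here means less inhibition, a higher number more inhibition at the concentration tested (going by the name of the read-out). Compound 2 gives the lower of the two; compound 1 stands higher, beyond the scatter. Compound 3 `CC1=CC[C@H](C(C)C)c2cc(C)c(OC(=O)c3ccccc3)cc21` is unmeasured. It differs from compound 2 by phenyl in place of anilino on a carbonyl carbon. Going by the values given here, no step between measured compounds bears on this change; the only guide is compound 1, which also carries a carbonyl bonded to an aromatic carbon rather than to nitrogen and gives 86%. A modest rise in this assay is therefore expected, possibly within the scatter. Compound 3 is estimated at 80% (range 62% to 92%), an expected step of a number 4.9 percentage points higher from compound 2 to compound 3 (within the scatter).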

Compound 3, a percentage reported as inhibition, at one concentration (the size of the read-out at that concentration, not a potency): 60.7%
Compound 3: the middle estimate sits 19.3 percentage points above what was measured, and the stated range ends above it.
By their numbers in this assay, from the lowest: compound 3; then compound 2; then compound 1.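

In this assay, phenyl in place of anilino on this carbonyl carbon gives a number 14.4 percentage points lower from compound 2 to compound 3 (beyond the scatter), so a carbonyl bonded to an aromatic carbon does not by itself carry the higher reading of compound 1. Within the two esters, hydrogen in place of trifluoromethyl on an aromatic carbon gives a number 25.3 percentage points lower from compound 1 to compound 3 (beyond the scatter). No measurement on hand explains either step.

Still open, from the compounds shown here alone, is whether chlorine or methoxy on that aromatic carbon would match trifluoromethyl, and how a longer alkyl chain in place of phenyl on the carbonyl carbon would read.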